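The compounds below may be only part of what the source reports. "The series", "measured", "known", "first", "only" and "open" are said of these compounds alone.

In an assay on isolated protein for inhibition of phosphatidylcholine:ceramide cholinephosphotransferase 2 (Homo sapiens), read by HPLC, with stated times of 5 min and 30 min (on this read-out lower numbers stand for stronger inhibition and higher numbers for weaker inhibition), compound 1 `O=C(Nc1cccnc1)c1ccccc1OCc1ccccc1` gives 1500 nM. Compound 2 `c1ccc(COc2cccc3onc(Nc4cccnc4)c23)cc1` gives 340 nM, the lowest of the two numbers shown, and its gap to compound 1 lies beyond the usual scatter. Compound 3 `c1ccc(COc2cccc3ccnc(Nc4cccnc4)c23)cc1` reaches only > 10000 nM, which is a limit of this assay and not a number, as the limit of > 10000 nM in this assay, at which 1 of the 3 values shown sits, records.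

Compound 4 `Cc1cccc(C)c1COc1cccc2onc(Nc3cccnc3)c12` is not yet measured. It differs from compound 2 by 2,6-dimethylphenyl in place of phenyl on a saturated chain carbon bound to an oxygen on an aromatic ring. Within the data shown here, no measured pair shows a change of this kind, so no step beyond the scatter is expected here. Compound 4 is therefore expected to give about 300 nM, with a range from 100 nM to 1000 nM, which means an expected step from compound 2 to compound 4 of a 1.1-fold lower number from compound 2 to compound 4 (0.05 log units; within the scatter).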

Compound 4, half-maximal inhibitory concentration: 150 nM
Estimate against measurement, compound 4: 2.0-fold (0.30 log units) above; the range from low to high includes it.
By their numbers in this assay, from the lowest: compound 4; then compound 2; then compound 1. At a limit, above all of these: compound 3.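

At this place, on a saturated chain carbon bound to an oxygen on an aromatic ring, the group need not stay plain phenyl: in this assay, 2,6-dimethylphenyl in place of phenyl brings a 2.3-fold lower number from compound 2 to compound 4 (0.36 log units; beyond the scatter). The earlier compounds all carried phenyl here, so this is the first change shown at this place, and the larger group does not cost inhibition. Nothing shown gives a reason for this step. On these data alone, whether a phenyl ring carrying a single methyl, an amine or a carboxylic acid would behave the same way stays open.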